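Swapping Methyl for Fluoro on Compound 1

The source may report more compounds than this note shows. Statements on the series, on what has been measured and on what is new or still open speak of the compounds shown alone.

In a functional assay on A-431 cells (Homo sapiens) for antiproliferative activity, read by sulforhodamine B assay, with a stated time of 72 h (a higher number here means a weaker inhibitor, a lower number a stronger inhibitor), compound 1 `C=C1CC(CBr)(c2ccccc2C)OC1=O` gives 5500 nM as its result. That lies within the usual scatter of compound 3 `C=C1CC(CBr)(c2ccc(OC)cc2)OC1=O` at 4200 nM and so these two cannot be told apart. Compound 2 `C=C1CC(CBr)(c2ccc(C)cc2)OC1=O` gives 2200 nM in the same test, a lower number than compound 1 by more than the scatter.

Compound 4 `C=C1CC(CBr)(c2ccccc2F)OC1=O` has not yet been measured. It differs from compound 1 by one small change: fluoro in place of methyl on an aromatic carbon and in words this is fluoro in place of methyl on an aromatic carbon.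

For the measured compounds named here, only one measured step also replaces a methyl on an aromatic carbon. That is a 1.9-fold higher number from compound 2 to compound 3 (0.28 log units; within the scatter) with methoxy as the entering group, and it stays within the scatter. Going by the values given here, no measured compound carries fluoro, so this step is only a loose guide. On that thin evidence, no step beyond the scatter is expected in this assay in either direction. The estimated change is a 1.4-fold lower number from compound 1 to compound 4 (0.14 log units; within the scatter) as a best guess. For compound 4 the expected value is 4000 nM with an estimated range of 1800 nM to 9000 nM in this test.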

Compound 4, half-maximal inhibitory concentration: 1700 nM
Estimate against measurement, compound 4: 2.4-fold (0.37 log units) above; measured number below the stated range.
By their numbers in this assay, from the lowest: compounds 4, 2, 3 and 1 (each within the scatter of the next, the first and the last beyond it).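

In this assay, the position on an aromatic carbon, ortho to a group of 9 heavy atoms, responds to this swap: a 3.2-fold lower number from compound 1 to compound 4 (0.51 log units; beyond the scatter) is a step beyond the scatter, so the number for this series can move when a single group on the ring changes. For the compounds shown here, the only earlier replacement of a methyl, a 1.9-fold higher number from compound 2 to compound 3 (0.28 log units; within the scatter), stayed within the scatter and could not show this, so the new step is the first clear sign that replacing a methyl can matter. The methyl and the fluoro count alike, each with one heavy atom, no ring, no hydrogen-bond donors or acceptors and no net charge, so those counts do not separate them, and no measurement here explains the difference.

The compounds shown leave open whether the lower number belongs to fluoro alone or would also appear with chloro, a hydroxyl, an amine, a carboxylic acid or a longer chain such as ethyl at this position. They also leave open whether fluoro in the place of the methyl of compound 2 would give a step of similar size.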